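The source may hold more compounds than are shown below. What is called first, only, known or untested is meant among the compounds shown, and "the series" means these compounds.

In a functional assay on FM3A cells (Mus musculus) for antiproliferative activity (a higher number here means a weaker inhibitor, a lower number a stronger inhibitor), three compounds on a shared core have been measured. Compound 1 `COc1cc(C(=O)c2sc(-c3ccc(Br)cc3)cc2N)cc(OC)c1OC` gives 150 nM and compound 2 `COc1cc(C(=O)c2sc(-c3ccc([N+](=O)[O-])cc3)cc2N)cc(OC)c1OC` gives 64 nM while compound 3 `COc1cc(C(=O)c2sc(-c3cccc([N+](=O)[O-])c3)cc2N)cc(OC)c1OC` gives 17 nM and is the strongest of the three. Compound 4 `COc1cc(C(=O)c2sc(-c3ccccc3Cl)cc2N)cc(OC)c1OC` is still unmeasured. It carries 2-chlorophenyl in place of 3-nitrophenyl on an aromatic carbon and so gives up the best group so far. The relevant steps are an 8.8-fold lower number from compound 1 to compound 3 (0.95 log units; beyond the scatter) and a 3.8-fold lower number from compound 2 to compound 3 (0.58 log units; beyond the scatter), both modest, with a 2.3-fold lower number from compound 1 to compound 2 (0.37 log units; beyond the scatter) also modest. Compound 3 thus sits at the low end, and a move back toward the number of compound 1 at 150 nM is expected. In this assay the estimated step is an 8.8-fold higher number from compound 3 to compound 4 (0.95 log units; beyond the scatter) upward. Compound 4 is estimated at 150 nM, with an expected range of 40 nM to 600 nM.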

Compound 4, half-maximal inhibitory concentration: 34 nM
Beside the measured number, compound 4's estimate is 4.4-fold (0.64 log units) above it; measured number outside the range, below it.
By their numbers in this assay, from the lowest: compounds 3, 4 and 2 (each within the scatter of the next, the first and the last beyond it); then compound 1.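

At this aromatic carbon next to the ring sulfur, this assay shows that a nitrophenyl group is not required for a low number: the result is a 2.0-fold higher number from compound 3 to compound 4 (0.30 log units; within the scatter) and a 1.9-fold lower number from compound 2 to compound 4 (0.27 log units; within the scatter) for the step to 2-chlorophenyl. A halogen-bearing phenyl can therefore stand with both nitrophenyl compounds, although compound 1 goes against this, with a 4.4-fold lower number from compound 1 to compound 4 (0.64 log units; beyond the scatter) as its step. On these data alone, whether a phenyl ring bearing an amine or a carboxylic acid would fit this pattern remains open. The data shown offer no explanation for these numbers.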